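From a Cyanomethyl Amide to an Alkynyl Ester

A few compounds are considered here, and "the series" means these few. Any claim that something is new, unique, unknown or untested is made for them only; others in the source may bear on it.

In a functional assay on Caco-2 cells (Homo sapiens) for antiproliferative activity, read by MTT assay, with a stated time of 48 h (a lower number here means a stronger inhibitor, a higher number a weaker inhibitor), compound 1 `CCn1c(C(=O)NCCN(C)C)ccc1C(CC)(CC)c1ccc(OCCC(O)(CC)CC)c(C)c1` gives 1140 nM. Compound 2 `CCn1c(C(=O)NCC#N)ccc1C(CC)(CC)c1ccc(OCCC(O)(CC)CC)c(C)c1` stands at > 50000 nM, which is a limit of the assay and not a number. Among the compounds with values here, the one measured step, an at least 43-fold higher number from compound 1 to compound 2 (1.64 log units; beyond the scatter), is large and puts cyano in place of (dimethylamino)methyl on a saturated chain carbon bound to an amide-type nitrogen. Compound 3 `C#CC(C)OC(=O)c1ccc(C(CC)(CC)c2ccc(OCCC(O)(CC)CC)c(C)c2)n1CC` brings a different change, ((1-methylprop-2-yn-1-yl)oxy in place of (cyanomethyl)amino on a carbonyl carbon), with (1-methylprop-2-yn-1-yl)oxy in place of (cyanomethyl)amino on a carbonyl carbon. Within the data shown here, no measured step covers this exact swap, but the step of an at least 43-fold higher number from compound 1 to compound 2 (1.64 log units; beyond the scatter) shows that changes in this part of the molecule can shift the number strongly in this assay. A moderate move towards a lower number is therefore expected, smaller than that step, and the estimated change is an at least 3.3-fold lower number from compound 2 to compound 3 (0.52 log units; beyond the scatter). For compound 3 the expected value is 15000 nM, within an estimated range of 3000 nM to 50000 nM.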

Compound 3, half-maximal inhibitory concentration: > 50000 nM
Compound 3 was reported as a limit; the forecaster's own chance of this, stated with the estimate: 35%; middle value at least 3.3-fold (0.52 log units) away from the limit.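

In this assay, putting (1-methylprop-2-yn-1-yl)oxy in place of (2-(dimethylamino)ethyl)amino on the carbonyl carbon gives an at least 43-fold higher number from compound 1 to compound 3 (1.64 log units; beyond the scatter). A second, quite different replacement for that side chain therefore also ends at the assay limit, so the weak result is not peculiar to the nitrile of compound 2: compound 3 has no nitrile-bearing amide and no amide hydrogen. The step between compound 2 and compound 3 cannot be read, because both are limits and not numbers: the limit of > 50000 nM in this assay, at which 2 of the 3 values shown sit.

As far as these compounds go, whether the dimethylamino group itself is what matters remains open, since only compound 1 carries it. Also open, from the compounds shown here alone, is how a diethylamino group, a primary amine or a longer chain ending in dimethylamino would behave on the same carbonyl carbon.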